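Extending an Ester Side Chain in an Angiotensin Receptor Series

The compounds below may be only part of what the source reports. "The series", "measured", "known", "first", "only" and "open" are said of these compounds alone.

Measured compounds in an assay on isolated protein for binding affinity to Type-2 angiotensin II receptor (Homo sapiens); on this read-out higher numbers stand for weaker inhibition and lower numbers for stronger inhibition:
compound 1, `CCCCCOC(=O)NS(=O)(=O)c1ccccc1-c1ccc(Cn2c(CCC)nc(CC)c2C(=O)OCCC(=O)Nc2ccccc2)c(F)c1`, 1 nM
compound 2, `CCCc1nc(CC)c(C(=O)OCC(=O)c2ccccc2)n1Cc1ccc(-c2ccccc2S(=O)(=O)NC(=O)OCCC(C)C)cc1F`, 2 nM
compound 3, `CCCc1nc(CC)c(C(=O)OC(C(=O)c2ccccc2)c2ccccc2)n1Cc1ccc(-c2ccccc2S(=O)(=O)NC(=O)OCCC(C)C)cc1F`, 3 nM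

Compound 2 stands in the middle of these three numbers: compound 3 sits a little higher and compound 1 a little lower, both within the scatter, so the three are not really distinguishable. Compound 4 `CCCc1nc(CC)c(C(=O)OCCCCOc2ccccc2)n1Cc1ccc(-c2ccccc2S(=O)(=O)NC(=O)OCCC(C)C)cc1F` differs from compound 2 by 3-phenoxypropyl in place of benzoyl on a saturated chain carbon bound to an oxygen next to a carbonyl group. Among the compounds with values here, the only step with a comparison at this place is a 1.5-fold higher number from compound 2 to compound 3 (0.18 log units; within the scatter), which changed the ester group without moving the number beyond the scatter. Since all three measured esters sit close together, the step of a 1.5-fold higher number from compound 2 to compound 4 (0.18 log units; within the scatter) is expected to stay small, with no clear direction. The estimated value for compound 4 is therefore 3 nM, with a range from 1 nM to 10 nM.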

Compound 4, half-maximal inhibitory concentration: 2 nM
Compound 4: the middle estimate sits 1.5-fold (0.18 log units) above what was measured, within the range that was stated.
By their numbers in this assay, from the lowest: compounds 1, 2, 4 and 3 (each within the scatter of the next, the first and the last beyond it).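

In this assay, putting 3-phenoxypropyl in place of benzoyl gives no change at the digits printed from compound 2 to compound 4 (within the scatter). The entering group has 10 heavy atoms against 8 and no double bond outside its aromatic ring, so in this pair neither the benzoyl carbonyl nor the smaller group is needed for a number in this range. Nothing measured here explains why the number holds. Still open, going by these compounds, is whether an amine or a carboxylic acid in place of 3-phenoxypropyl would keep the number in this range, and whether a longer chain would.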